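Adding a Phenyl to the Methylamino Side Chain

The compounds below may be only part of what the source reports. "The series", "measured", "known", "first", "only" and "open" are said of these compounds alone.

Compound 1, `COc1cc(OC)n2cc(-c3ccc([N+](=O)[O-])cc3)nc2n1`, gives 36600 nM in a functional assay on A549 cells (Homo sapiens) for antiproliferative activity, read by MTT assay, with a stated time of 72 h; a higher number here means a weaker inhibitor of growth, a lower number a stronger inhibitor of growth.
Compound 2, `COc1cc(OC)n2cc(-c3ccc(N)cc3)nc2n1`, reaches only a limit in this assay, namely > 100000 nM.
Compound 3, `CNc1ccc(-c2cn3c(OC)cc(OC)nc3n2)cc1`, likewise reaches only a limit in this assay, namely > 100000 nM.

Compound 3 therefore stands at the top end of what this assay reports, with no exact number; one other value shown sits at that same limit (the limit of > 100000 nM in this assay, at which 2 of the 3 values shown sit). The change to compound 4, `COc1cc(OC)n2cc(-c3ccc(NCc4ccccc4)cc3)nc2n1`, is phenyl in place of hydrogen on a saturated chain carbon bound to a nitrogen on an aromatic ring. Among the compounds with values here, two measured steps bear on this position of the molecule: an at least 2.7-fold higher number from compound 1 to compound 2 (0.43 log units; beyond the scatter) and an at least 2.7-fold higher number from compound 1 to compound 3 (0.43 log units; beyond the scatter). Both show that swapping the nitro for an amine on that aromatic carbon weakens growth inhibition by at least a modest amount. The direct comparison a step that the two limits leave unreadable from compound 2 to compound 3 gives no readable size, so adding one carbon to that nitrogen left no measurable trace. Within the data shown here, no measured step tells what a larger group on that nitrogen does. The expectation for compound 4 is thus a number at or near the limit, with only a modest chance of a readable value: the estimate is 80000 nM, within 20000 nM to 200000 nM, which corresponds to an expected step of an at least 1.2-fold lower number from compound 3 to compound 4 (0.09 log units; that floor lies within the scatter).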

Compound 4, concentration for 50% growth inhibition: > 100000 nM
Compound 4: a limit, no number (the forecaster's own chance of this, stated with the estimate: 55%); at least 1.2-fold (0.09 log units) between middle value and limit.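

The benzyl group is far larger than the hydrogen or methyl on that nitrogen in the earlier compounds, yet compound 4 still gives no exact number in this assay and joins them at the same limit: the limit of > 100000 nM in this assay, at which 3 of the 4 values shown sit.

Compound 2, compound 3 and compound 4 are all limits, so the steps among them cannot be read, and any real differences among these three compounds stay hidden. Within the data shown here, the one readable step is an at least 2.7-fold higher number from compound 1 to compound 4 (0.43 log units; beyond the scatter), which shows that benzylamino in place of nitro on that aromatic carbon weakens growth inhibition by at least a modest amount, as amino and methylamino did, so adding a phenyl to the methylamino side chain does not bring back a readable value.

On these data alone, what an acetyl on that nitrogen or a longer chain ending in phenyl would do remains open. Also open, as far as these compounds go, is whether a nitrile or a carboxylic acid on that aromatic carbon would match the readable value of compound 1 or fall to the same limit.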